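This account rests on a few compounds, and the source may have more. Where it says the series, first, only, none or still open, it means among the compounds named here.

Measured compounds in an assay on HL-60 cells for inhibition of glutathione S-transferase P (Homo sapiens); a higher number here means a weaker inhibitor, a lower number a stronger inhibitor:
- compound 1, `C=C(C)C(=O)c1ccc(OCc2nc(-c3ccc([N+](=O)[O-])cc3)no2)cc1C`, 2900 nM
- compound 2, `C=C(C)C(=O)c1ccc(OCc2nc(-c3ccc(C(F)(F)F)cc3)no2)cc1Cl`, 700 nM
- compound 3, `C=C(CC)C(=O)c1ccc(OCc2nc(C)no2)c(Cl)c1Cl`, 4000 nM

Compound 3 sits at the upper edge of these three numbers. Its value and that of compound 1 lie within the usual scatter of each other, so no order between them can be read. Compound 2 alone stands clearly apart, its number well below that of compound 3.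

Compound 4, `C=C(CC)C(=O)c1ccc(OCc2nc(-c3ccc(Cl)cc3)no2)c(Cl)c1Cl`, has not yet been measured in this assay. It is compound 3 with one change: 4-chlorophenyl in place of methyl on an aromatic carbon. Within the data shown here, no measured pair shows this exact change. Among the measured compounds shown here, compound 2, which carries an aryl group at the same ring position, is the only compound with a clearly lower number, so a decrease beyond the scatter is expected, a 4.0-fold lower number from compound 3 to compound 4 (0.60 log units; beyond the scatter). Compound 4 is estimated at 1000 nM, between 300 nM and 3000 nM.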

Compound 4, half-maximal inhibitory concentration: 5400 nM
Compound 4: middle estimate off by 5.4-fold (0.73 log units), on the low side; measured number above the stated range.
By their numbers in this assay, from the lowest: compound 2; then compounds 1, 3 and 4 (each within the scatter of the next).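

In this assay, among these compounds, 4-chlorophenyl in place of methyl on the aromatic carbon between two ring nitrogen atoms gives a 1.4-fold higher number from compound 3 to compound 4 (0.13 log units; within the scatter), the first direct reading at this position. In this pair, replacing one heavy atom with seven and adding an aromatic ring produces no readable change, so an aryl group here does not by itself lower the number. No measured data bear on the reason for this result.

From the compounds shown here alone, whether an amine, a carboxylic acid or a longer alkyl chain on this carbon would shift the number stays open. So does whether this change reads the same with other substituents on the core.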